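The source may hold more compounds than are shown below. What is called first, only, known or untested is meant among the compounds shown, and "the series" means these compounds.

In a functional assay on ME-180 cells (Homo sapiens) for cytotoxicity, read by MTT assay, with a stated time of 72 h (on this read-out lower numbers stand for stronger inhibition and higher numbers for weaker inhibition), the measured compounds are: compound 1 `COc1ccc(C(=O)c2cc(OC)c(OC)c(OC)c2)cc1N` with 80 nM; compound 2 `COc1cccc(/C=C/C(=O)Nc2cc(OC)c(OC)c(OC)c2)c1` with 17300 nM; compound 3 `C#CCOc1cccc(/C=C/C(=O)Nc2cc(C(=O)c3cc(OC)c(OC)c(OC)c3)ccc2OC)c1` with 15300 nM.

Compound 3 stands second highest of these three numbers. Its nearest neighbour is compound 2, a gap within the usual scatter; compound 1 lies far lower, well beyond the scatter. Compound 4 `COc1ccc(C(=O)c2cc(OC)c(OC)c(OC)c2)cc1NC(=O)/C=C/c1ccc(N)cc1` differs from compound 3 by 4-aminophenyl in place of 3-(propargyloxy)phenyl on a double-bonded chain carbon bound to a double-bonded chain carbon. Within the data shown here, no measured pair isolates this swap, so the expectation rests on the fact that compound 2 and compound 3, which both carry the amide-linked chain, give high numbers in this assay. The step from compound 3 to compound 4 is expected to be a 1.9-fold lower number from compound 3 to compound 4 (0.28 log units; within the scatter), no change beyond the scatter. Compound 4 is therefore estimated at 8000 nM, with a range from 1500 nM to 40000 nM.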

Compound 4, half-maximal inhibitory concentration: 16000 nM
For compound 4 the middle estimate is 2.0-fold (0.30 log units) below the measured one; the range from low to high includes it.
By their numbers in this assay, from the lowest: compound 1; then compounds 3, 4 and 2 (each within the scatter of the next).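

In this assay the swap at this place gives a 1.0-fold higher number from compound 3 to compound 4 (0.02 log units; within the scatter) and so 4-aminophenyl and 3-(propargyloxy)phenyl read alike here. Among these compounds, putting (2-(4-aminophenyl)ethenyl)carbonyl in place of hydrogen on the nitrogen gives a 200-fold higher number from compound 1 to compound 4 (2.30 log units; beyond the scatter) and this single-place step links the large rise in the number to that added chain, a link the earlier compounds could not show. No measurement available here explains either step.

Still open, from the compounds shown here alone, is whether a much shorter group on that nitrogen, such as acetyl, would stay close to compound 1. Also open, going by these compounds, is whether a carboxylic acid in place of the amine on the phenyl ring would change the number at all.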